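Replacing the 2-chlorophenyl group of compound 3

This account rests on a few compounds, and the source may have more. Where it says the series, first, only, none or still open, it means among the compounds named here.

Of the compounds shown here, three sharing one core have been measured in a functional assay on MCF7 cells (Homo sapiens) for inhibition, read by MTT assay; on this read-out lower numbers stand for stronger inhibition and higher numbers for weaker inhibition. There, compound 1 (`COc1cc2ncnc(Nc3ccc(NC(=O)c4ccc(C)cc4)cc3)c2cc1OC`) gives 19000 nM, compound 2 (`COc1cc2ncnc(Nc3ccc(NC(=O)c4cccc(F)c4)cc3)c2cc1OC`) gives 13600 nM and compound 3 (`COc1cc2ncnc(Nc3ccc(NC(=O)c4ccccc4Cl)cc3)c2cc1OC`) gives 36000 nM. Compound 3 stands clearly apart from only one of the others. The data show a 2.6-fold higher number from compound 2 to compound 3 (0.42 log units; beyond the scatter), whereas they show a 1.9-fold higher number from compound 1 to compound 3 (0.28 log units; within the scatter).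

The next structure is compound 4 (`COc1cc2ncnc(Nc3ccc(NC(=O)c4cccc(C(F)(F)F)c4)cc3)c2cc1OC`), which keeps the shared core and differs from compound 3 on the carbonyl carbon whose other neighbour is an amide-type nitrogen: 3-(trifluoromethyl)phenyl in place of 2-chlorophenyl on a carbonyl carbon. Among the measured compounds shown here, no measured compound carries the 3-(trifluoromethyl)phenyl group, so any expectation rests on neighbouring changes. The most relevant is a 2.6-fold higher number from compound 2 to compound 3 (0.42 log units; beyond the scatter), read in reverse, as compound 2 has the 3-fluorophenyl group, the measured group closest in name to the incoming one. The other step that bears on it, a 1.4-fold lower number from compound 1 to compound 2 (0.15 log units; within the scatter), suggests that replacing one group with another need not move the number far. A modest move towards a lower number is therefore expected in this assay, and the estimate is a 2.1-fold lower number from compound 3 to compound 4 (0.33 log units; beyond the scatter). Compound 4 is estimated at 17000 nM, with an expected range from 8000 nM to 36000 nM.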

Compound 4, half-maximal inhibitory concentration: > 100000 nM
Compound 4 was reported as a limit; the forecaster's own chance of this, stated with the estimate: 3%; middle value at least 5.8-fold (0.76 log units) away from the limit.
By their numbers in this assay, from the lowest: compounds 2, 1 and 3 (each within the scatter of the next, the first and the last beyond it). At a limit, above all of these: compound 4.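

Compound 4 is the first compound here to reach a limit of the assay rather than a number: the limit of > 100000 nM in this assay, at which 1 of the 4 values shown sits.

Trifluoromethyl in place of fluoro on an aromatic carbon gives an at least 7.3-fold higher number from compound 2 to compound 4 (0.86 log units; beyond the scatter), so a change within a single group on the carbonyl carbon can matter far more in this assay than the first three compounds suggested. The other two changes point the same way, with an at least 2.7-fold higher number from compound 3 to compound 4 (0.44 log units; beyond the scatter) and an at least 5.2-fold higher number from compound 1 to compound 4 (0.72 log units; beyond the scatter), and each of the three goes further than the largest earlier step, a 2.6-fold higher number from compound 2 to compound 3 (0.42 log units; beyond the scatter).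

On these data alone, how far compound 4 lies past its limit stays open, and with it the true size of all three steps. Also open, as far as these compounds go, is whether an amine or a nitrile in place of the trifluoromethyl would keep the number near that of compound 2 or push it towards the limit reached by compound 4.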